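A single group exchanged on compound 2

The compounds below may be only part of what the source reports. "The series", "measured", "known", "first", "only" and "open" are said of these compounds alone.

Compound 1 `COc1ccc(-c2ccc(-c3ccc(-c4nc5ccccc5[nH]4)cc3)cc2)cc1`: 100000 nM
Compound 2 `Oc1cccc2[nH]c(-c3ccc(-c4ccc(-c5ccc(F)cc5)cc4)cc3)nc12`: 41200 nM

In a functional assay on A2780 cells (Homo sapiens) for inhibition, read by sulforhodamine B assay (on this read-out lower numbers stand for stronger inhibition of growth and higher numbers for weaker inhibition of growth), compound 2 has the lower number of the two, and its gap to compound 1 lies beyond the usual scatter. Compound 3 `Oc1cccc2[nH]c(-c3ccc(-c4ccc(-c5cccc(Cl)c5)cc4)cc3)nc12` differs from compound 2 in one place: 3-chlorophenyl in place of 4-fluorophenyl on an aromatic carbon. Among the measured compounds shown here, no measured pair shows what such an exchange does. The closest guide is compound 2 itself, at 41200 nM, so no step beyond the scatter is expected in this assay, and neither direction is favoured. The expected change is small: a 1.0-fold lower number from compound 2 to compound 3 (0.01 log units; within the scatter). For compound 3 the estimated value is 40000 nM, with an expected range from 15000 nM to 100000 nM.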

Compound 3, concentration for 50% growth inhibition: 2800 nM
Compound 3: the middle estimate sits 14-fold (1.15 log units) above what was measured, and the stated range ends above it.
By their numbers in this assay, from the lowest: compound 3; then compound 2; then compound 1.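

In this assay, the outer ring of compound 2 turns out to be a sensitive place: 3-chlorophenyl in place of 4-fluorophenyl gives a 15-fold lower number from compound 2 to compound 3 (1.17 log units; beyond the scatter). This large step comes from an exchange that keeps the six-membered aromatic ring of carbon only and adds no hydrogen-bond donor, hydrogen-bond acceptor or net charge. No measurement at hand explains it.

The exchange swaps the halogen and moves it at once, so these compounds cannot show which of the two matters. As far as these compounds go, how an amine or a carboxylic acid would fare on this ring also remains open.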